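This account rests on a few compounds, and the source may have more. Where it says the series, first, only, none or still open, it means among the compounds named here.

In a functional assay on A549 cells (Homo sapiens) for cytotoxicity, read by MTT assay, with a stated time of 72 h (on this read-out lower numbers stand for stronger inhibition and higher numbers for weaker inhibition), three compounds have been measured so far. Compound 1, `Cc1cc(=O)n(-c2cccc(F)c2)nc1C(=O)Nc1ccc(Oc2ncnc3ccsc23)cc1`, gives 9540 nM in this assay. Compound 2, `Cc1cc(=O)n(-c2cccc(F)c2)nc1C(=O)Nc1ccc(Oc2ncnc3ccsc23)c(F)c1`, gives 5220 nM in this assay. The two differ in one place, (fluoro in place of hydrogen on an aromatic carbon), and that change made a 1.8-fold lower number from compound 1 to compound 2 (0.26 log units; within the scatter). Compound 3, `Cc1cc(=O)n(-c2ccc(F)cc2)nc1C(=O)Nc1ccc(Oc2ncnc3sccc23)c(F)c1`, gives 2620 nM in this assay; its number is the lowest of the three, with its gap to compound 1 beyond the scatter and its gap to compound 2 within it. The difference between the core of compound 1 and the core of compound 3 is not broken down here.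

Compound 4, `Cc1cc(=O)n(-c2ccc(F)c(F)c2)nc1C(=O)Nc1ccc(Oc2ncnc3sccc23)c(F)c1`, awaits measurement. It differs from compound 3 by fluoro in place of hydrogen on an aromatic carbon. Within the data shown here, this is the same kind of change as the one from compound 1 to compound 2, but the surroundings are not identical: in compound 2 the entering fluoro sits ortho to a large group and meta to a large group, whereas in compound 4 it sits ortho to a fluoro group and meta to a large group. Cut one bond further out, the change in compound 4 reads 4-fluorophenyl to 3,4-difluorophenyl.

Because a 1.8-fold lower number from compound 1 to compound 2 (0.26 log units; within the scatter) stayed within the scatter, a step of similar size is expected here. Compound 4 is expected to show a 1.5-fold lower number from compound 3 to compound 4 (0.16 log units; within the scatter) in this assay. Compound 4 is estimated at 1800 nM in this assay. Compound 4 is expected to fall between 900 nM and 3600 nM in this assay.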

Compound 4, half-maximal inhibitory concentration: 15700 nM
Estimate against measurement, compound 4: 8.7-fold (0.94 log units) below; measured number outside the range, above it.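

In this assay, fluoro in place of hydrogen on an aromatic carbon, here 4-fluorophenyl to 3,4-difluorophenyl, gave a 6.0-fold higher number from compound 3 to compound 4 (0.78 log units; beyond the scatter), so the small shift seen earlier did not carry over to this second case. Set beside the earlier step, the two outcomes differ, and in this series the change cannot be treated as having one transferable size or direction: the same change on two cores in this assay, a 1.8-fold lower number (0.26 log units; within the scatter) from compound 1 to compound 2 and a 6.0-fold higher number (0.78 log units; beyond the scatter) from compound 3 to compound 4, 11-fold (1.04 log units) apart, beyond the scatter of two such steps. Among these compounds, this does not show what drives the gap, since each core contributes only a single pair, and the two pairs differ in their cores and also in where the fluoro enters, which in compound 4 is ortho to a fluoro group and meta to a large group, so the effects of core and surroundings cannot be separated.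

From the compounds shown here alone, it remains open whether 4-fluorophenyl to 3,4-difluorophenyl would give a similar rise on the core of compound 1, which would show whether the core or the place of the fluoro matters. The compounds shown also leave open how a chloro group, a methoxy group or an amine in the place of the entering fluoro would read in this assay.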